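Second trifluoromethyl on the urea aryl of compound 1

This account rests on a few compounds, and the source may have more. Where it says the series, first, only, none or still open, it means among the compounds named here.

Measured compounds:
- compound 1, `O=C(Nc1cccc(-n2cc(-c3ccncc3)c(-c3ccc(Cl)c(O)c3)n2)c1)Nc1cccc(C(F)(F)F)c1`, 1910 nM
- compound 2, `COc1cc(-c2nn(-c3cccc(NC(=O)c4cccc(C(F)(F)F)c4)c3)cc2-c2ccncc2)ccc1Cl`, 2460 nM
- compound 3, `O=C(Nc1cccc(-n2cc(-c3ccncc3)c(-c3ccc(Cl)c(O)c3)n2)c1)Nc1ccc(Cl)c(Cl)c1`, 1460 nM

All three numbers come from a functional assay on SNB-19 cells (Homo sapiens) for inhibition, read by sulforhodamine B assay, with a stated time of 48 h; on this read-out lower numbers stand for stronger inhibition of growth and higher numbers for weaker inhibition of growth. Compound 1 stands second highest of the three; its nearest neighbour is compound 2, whose value in this assay differs from it within the scatter, and compound 3 also lies within the scatter of compound 1. Compound 2 is not a single-change partner of compound 1; its value is simply recorded alongside.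

The unmeasured compound is compound 4, `O=C(Nc1cccc(-n2cc(-c3ccncc3)c(-c3ccc(Cl)c(O)c3)n2)c1)Nc1cc(C(F)(F)F)cc(C(F)(F)F)c1`. It differs from compound 1 by trifluoromethyl in place of hydrogen on an aromatic carbon, that is, a second trifluoromethyl on the urea aryl ring.

Among the measured compounds shown here, the only single-change step on this aryl ring is a 1.3-fold lower number from compound 1 to compound 3 (0.12 log units; within the scatter). Replacing the whole 3-(trifluoromethyl)phenyl by 3,4-dichlorophenyl left the number within the scatter, so a further substituent on the same ring is expected to move it little. The step expected is a 1.1-fold lower number from compound 1 to compound 4 (0.03 log units; within the scatter), with no change beyond the scatter. Compound 4 is therefore estimated at 1800 nM, between 800 nM and 4000 nM.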

Compound 4, concentration for 50% growth inhibition: 983 nM
Compound 4: the middle estimate sits 1.8-fold (0.26 log units) above what was measured; low and high end bracket the measured number.
By their numbers in this assay, from the lowest: compounds 4, 3, 1 and 2 (each within the scatter of the next, the first and the last beyond it).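

In this assay, adding a second trifluoromethyl gives a 1.9-fold lower number from compound 1 to compound 4 (0.29 log units; within the scatter). Among the compounds shown here, compound 3 showed only that one substituted aryl group could replace another; compound 4 shows that this aromatic carbon, meta to a large group and meta to a trifluoromethyl group, accepts a group of 4 heavy atoms in place of hydrogen without the number moving beyond the scatter. No measurement among these compounds bears on why the number falls where it does.

Going by these compounds, whether an amine or a carboxylic acid at the same aromatic carbon would also stay within the scatter remains open. Also open, on these data alone, is whether the same addition would give a similar step on the amide of compound 2.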